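This account rests on a few compounds, and the source may have more. Where it says the series, first, only, none or still open, it means among the compounds named here.

In an assay on isolated protein for antagonist activity at Substance-P receptor (Homo sapiens) (a lower number here means a stronger inhibitor, a higher number a weaker inhibitor), the three measured compounds stand as follows:

Compound 1 `CCN(CC)C1CCC(COCc2cc(C(F)(F)F)cc(C(F)(F)F)c2)(c2ccccc2)CC1`: 38 nM
Compound 2 `FC(F)(F)c1cc(COCC2(c3ccccc3)CCC(N3CCCCC3)C2)cc(C(F)(F)F)c1`: 4.7 nM
Compound 3 `CN(C)C1CCC(COCc2cc(C(F)(F)F)cc(C(F)(F)F)c2)(c2ccccc2)C1`: 8 nM

Compound 3 sits second highest of these three numbers. Its nearest neighbour is compound 2, and the gap between them, a 1.7-fold higher number from compound 2 to compound 3 (0.23 log units; within the scatter), is no more than repeated measurements would give. Compound 1, whose core differs from that of compound 3 in more than one place, shows a number clearly higher than compound 3.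

Compound 4 `FC(F)(F)c1cc(COCC2(c3ccccc3)CCC(N3CCCC3)C2)cc(C(F)(F)F)c1` is the next step. Within the data shown here, its only change against compound 3 is pyrrolidin-1-yl in place of dimethylamino on a saturated ring carbon. Among the measured compounds shown here, the one measured step that speaks to this place is the exchange from compound 2 to compound 3, where a piperidin-1-yl gave way to a dimethylamino without moving the number beyond the scatter. The pyrrolidin-1-yl of compound 4 is a ring of the same kind as the piperidin-1-yl, only one atom smaller, so the step from compound 3 to compound 4 is expected to be small as well, a 1.3-fold lower number from compound 3 to compound 4 (0.12 log units; within the scatter). Compound 4 is therefore estimated at 6 nM, with a likely range from 3 nM to 14 nM.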

Compound 4, half-maximal inhibitory concentration: 14 nM
Compound 4: middle estimate off by 2.3-fold (0.37 log units), on the low side; low and high end bracket the measured number.
By their numbers in this assay, from the lowest: compounds 2, 3 and 4 (each within the scatter of the next, the first and the last beyond it); then compound 1.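

In this assay, putting pyrrolidin-1-yl in place of dimethylamino on this saturated ring carbon gives a step that stays small (a 1.8-fold higher number from compound 3 to compound 4 (0.24 log units; within the scatter)), so these two groups cannot be told apart here. Among these compounds, the new information lies in the comparison of the two ring amines (a 3.0-fold higher number from compound 2 to compound 4 (0.47 log units; beyond the scatter)), which is the first single change at this position to pass the scatter, though only modestly, and it shows that the number can respond to the ring on this nitrogen even though dimethylamino stays within the scatter of both rings. Nothing measured here bears on why the two rings differ.

The compounds shown leave open how a seven-membered azepan-1-yl ring or a morpholin-4-yl ring would behave at this carbon. They also leave open whether a primary amine or a hydroxyl group could stand in for these tertiary amines.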